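The source may hold more compounds than are shown below. What is called first, only, known or untested is meant among the compounds shown, and "the series" means these compounds.

Measured compounds in the series so far:

compound 1 `CC(C)(C)c1ccc(C(=O)N2CCC3(CC2)C(=O)N(CC(=O)NCCO)CN3c2ccccc2)cc1` gives 1000 nM in an assay on HEK293 cells for displacement of a labelled ligand from NPC1-like intracellular cholesterol transporter 1 (Homo sapiens); a lower number here means a stronger inhibitor, a higher number a weaker inhibitor
compound 2 `CC1CCCN(C(=O)CN2CN(c3ccccc3)C3(CCN(C(=O)c4ccc(C(C)(C)C)cc4)CC3)C2=O)C1` gives 12000 nM in this assay
compound 3 `CC(C)(C)c1ccc(C(=O)N2CCC3(CC2)C(=O)N(CC(=O)N2CCC(O)CC2)CN3c2ccccc2)cc1` gives 4700 nM in this assay

Compound 3 stands second highest of the three numbers. Its nearest neighbour is compound 2, the step being a 2.6-fold lower number from compound 2 to compound 3 (0.41 log units; beyond the scatter); its furthest is compound 1, the step being a 4.7-fold higher number from compound 1 to compound 3 (0.67 log units; beyond the scatter).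

Compound 4 `CC(C)(C)c1ccc(C(=O)N2CCC3(CC2)C(=O)N(CC(=O)NCCCCNS(C)(=O)=O)CN3c2ccccc2)cc1` is the next candidate. The change from compound 3 is (4-(methanesulfonamido)butyl)amino in place of 4-hydroxypiperidin-1-yl on a carbonyl carbon. Going by the values given here, two measured steps bear on this. a 4.7-fold higher number from compound 1 to compound 3 (0.67 log units; beyond the scatter) shows that replacing an open-chain amino group bearing a hydroxyl by the 4-hydroxypiperidin-1-yl ring raised the number modestly, and a 12-fold higher number from compound 1 to compound 2 (1.08 log units; beyond the scatter) shows a large rise on going to the 3-methylpiperidin-1-yl ring; the step between the two rings, a 2.6-fold lower number from compound 2 to compound 3 (0.41 log units; beyond the scatter), is modest. Compound 4 returns to an open-chain amino group, now carrying a methanesulfonamide in place of the hydroxyl. The step is therefore expected to run downward, of roughly the size seen between the ring and the open chain, a 3.1-fold lower number from compound 3 to compound 4 (0.50 log units; beyond the scatter). Among the compounds with values here, no measured step covers the methanesulfonamide itself, so the range is kept wide.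

Compound 4 is expected to give 1500 nM in this assay, within the range 500 nM to 5000 nM.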

Compound 4, half-maximal inhibitory concentration: 4500 nM
Estimate against measurement, compound 4: 3.0-fold (0.48 log units) below; low and high end bracket the measured number.
By their numbers in this assay, from the lowest: compound 1; then compounds 4 and 3 (each within the scatter of the next); then compound 2.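

In this assay, going back to an open chain on the carbonyl carbon does not by itself bring the number back towards that of compound 1: the (4-(methanesulfonamido)butyl)amino group and the 4-hydroxypiperidin-1-yl ring cannot be told apart, with a 1.0-fold lower number from compound 3 to compound 4 (0.02 log units; within the scatter). Going by these compounds alone, compound 4 therefore goes against any reading of the earlier compounds in which open chains simply give lower numbers than rings, since there is a 4.5-fold higher number from compound 1 to compound 4 (0.65 log units; beyond the scatter) with both side chains open, while the 3-methylpiperidin-1-yl group remains clearly separate, with a 2.7-fold lower number from compound 2 to compound 4 (0.43 log units; beyond the scatter). No measured evidence accounts for these steps.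

Still open, as far as these compounds go, is whether the step from compound 1 follows the longer chain or the methanesulfonamide end group, as these change together; a 4-hydroxybutyl group or a 2-(methanesulfonamido)ethyl group on the amide nitrogen would separate the two. Also open, from the compounds shown here alone, is how a primary amine or a carboxylic acid at the end of the chain would compare with the hydroxyl of compound 1.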